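The source may report more compounds than this note shows. Statements on the series, on what has been measured and on what is new or still open speak of the compounds shown alone.

Compound 1 `Cc1ccsc1CN[C@@H]1C[C@H]2C[C@@H]([C@H]1C)C2(C)C` gives 10000 nM in an ADME assay on MDCK cells (Canis lupus familiaris) for cytotoxicity, read by microscopy, with a stated time of 48 h; a higher number here means that more compound is tolerated, a lower number that less compound is tolerated. Compound 2 `C[C@H]1[C@H](NCc2cncnc2)C[C@H]2C[C@@H]1C2(C)C` sits at the limit of this assay, > 100000 nM, a bound rather than a number. Within the data shown here, the one measured step, an at least 10-fold higher number from compound 1 to compound 2 (1.00 log units; beyond the scatter), is open-ended because of the limit of > 100000 nM in this assay, at which 1 of the 2 values shown sits. Compound 3 `Cc1n[nH]cc1CN[C@@H]1C[C@H]2C[C@@H]([C@H]1C)C2(C)C` differs from compound 2 by 3-methyl-1H-pyrazol-4-yl in place of pyrimidin-5-yl on a saturated chain carbon bound to an amine nitrogen. Among the measured compounds shown here, no measured step covers this exchange, and the move in compound 1 already ran into the bound. For compound 3 the expected step is an at least 1.4-fold lower number from compound 2 to compound 3 (0.15 log units; that floor lies within the scatter). Compound 3 is therefore estimated at 70000 nM in this assay, within 20000 nM to 100000 nM, with a fair chance of again reaching only a limit.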

Compound 3, minimum cytotoxic concentration: > 100000 nM
Compound 3: no number, only a limit (the forecaster's own chance of this, stated with the estimate: 50%); middle value at least 1.4-fold (0.15 log units) from the limit.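

In this assay compound 3 also gives only a limit, > 100000 nM. A second replacement of 3-methylthiophen-2-yl on a saturated chain carbon bound to an amine nitrogen, here by 3-methyl-1H-pyrazol-4-yl, gives an at least 10-fold higher number from compound 1 to compound 3 (1.00 log units; beyond the scatter), and this ring has a hydrogen-bond donor, whereas pyrimidin-5-yl has none. The step between compound 2 and compound 3 cannot be read because both values are limits: the limit of > 100000 nM in this assay, at which 2 of the 3 values shown sit.

As far as these compounds go, how far compound 2 and compound 3 actually lie apart remains open. So does whether a phenyl ring at this place would also reach the limit or stay closer to compound 1.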